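The source may hold more compounds than are shown below. What is called first, only, known or untested is meant among the compounds shown, and "the series" means these compounds.

Measured in an in vitro ADME assay on microsomes from liver (Homo sapiens) for metabolic stability, read by LC-MS; on this read-out lower numbers stand for a shorter-lived compound and higher numbers for a longer-lived compound:
- compound 1 `CC(C)N1C(=O)C(=O)N=C1/N=C(\NOCc1ccccc1)Nc1ccc(Cl)c(Cl)c1`: 0.215 h
- compound 2 `CC(C)N/C(=N\C1=NC(=O)C(=O)N1C(C)C)Nc1ccc(Cl)c(Cl)c1`: > 1 h (a limit)
- compound 3 `CC(C)N1C(=O)C(=O)N=C1/N=C(\NCc1ccccc1)Nc1ccc(Cl)c(Cl)c1`: > 1 h (a limit)

Compound 3 has no exact place on this scale, as its result is only a limit. It stands at the limit of > 1 h in this assay, at which 2 of the 3 values shown sit.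

The next compound, compound 4 `CC(C)N1C(=O)C(=O)N=C1/N=C(\NCCN(C)C)Nc1ccc(Cl)c(Cl)c1`, has not yet been measured. It has (dimethylamino)methyl in place of phenyl on a saturated chain carbon bound to an amine nitrogen. Read one bond further out, benzyl becomes 2-(dimethylamino)ethyl.

Going by the values given here, three measured steps bear on this change. Putting isopropyl in place of benzyloxy gave an at least 4.6-fold higher number from compound 1 to compound 2 (0.66 log units; beyond the scatter). Putting benzyl in place of benzyloxy gave an at least 4.6-fold higher number from compound 1 to compound 3 (0.66 log units; beyond the scatter). Both lie beyond the scatter, and compound 4 has no benzyloxy group either. The closest comparison is a swap of one group for another on the amine nitrogen, which gave a step that the two limits leave unreadable from compound 2 to compound 3. Among the compounds with values here, it shows only that both compounds reach the limit, so it cannot give an exact size.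

No step beyond the scatter is therefore expected, and a second limit is quite possible. The estimated step is a step that the limit leaves unreadable from compound 3 to compound 4. For compound 4, the expected half-life is 1.2 h, with an estimated range from 0.5 h to 3 h.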

Compound 4, half-life: > 1 h
Compound 4: only a limit was reported; the forecaster's own chance of this, stated with the estimate: 60%; the middle value is on the limit's open side.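

In this assay compound 4 gives > 1 h, and this value is a limit. At this position on the amine nitrogen, the earlier limit results came only with the all-carbon groups isopropyl and benzyl, whereas compound 4 reaches the limit with 2-(dimethylamino)ethyl, which has no ring and carries a nitrogen, and benzyloxy replaced by this group gives an at least 4.6-fold higher number from compound 1 to compound 4 (0.66 log units; beyond the scatter). The steps among compounds 2, 3 and 4 cannot be read, so all that can be said of these three compounds is that they share one ceiling: the limit of > 1 h in this assay, at which 3 of the 4 values shown sit.

Exact half-lives for compounds 2, 3 and 4 would be needed to rank them, so it stays open whether the swap from phenyl to (dimethylamino)methyl changes the half-life at all. On these data alone, it also stays open how far this result extends to other groups at this position, such as a longer chain ending in a dimethylamino group, a morpholine ring or a carboxylic acid, and whether a small methoxy group would sit as low as the benzyloxy group of compound 1.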